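From compound 2 to compound 3: fluoro to chloro

The source may report more compounds than this note shows. Statements on the series, on what has been measured and on what is new or still open speak of the compounds shown alone.

Compound 1 `CC1=CC[C@H](C(C)(C)NC(=S)N/N=C/c2ccccc2)CC1` gives 47600 nM in a functional assay on K562 cells (Homo sapiens) for inhibition, read by sulforhodamine B assay, with a stated time of 48 h; on this read-out lower numbers stand for stronger inhibition of growth and higher numbers for weaker inhibition of growth. Compound 2 `CC1=CC[C@H](C(C)(C)NC(=S)N/N=C/c2ccc(F)cc2)CC1` reaches only the limit of the assay, > 100000 nM, in this assay; this is a limit and not a number. Among the compounds with values here, the single measured step, an at least 2.1-fold higher number from compound 1 to compound 2 (0.32 log units; beyond the scatter), is thus anchored on (the limit of > 100000 nM in this assay, at which 1 of the 2 values shown sits), and compound 2 stands at the weak end of the two values shown, with only a limit known for it. Compound 3 `CC1=CC[C@H](C(C)(C)NC(=S)N/N=C/c2ccccc2Cl)CC1` differs from compound 2 by 2-chlorophenyl in place of 4-fluorophenyl on a carbon with a double bond to nitrogen. Within the data shown here, no measured step covers this change; the only step available, an at least 2.1-fold higher number from compound 1 to compound 2 (0.32 log units; beyond the scatter), concerns a different halogen on a different carbon and rests on a limit. A step in this assay of either direction is possible, and none beyond the scatter can be predicted with confidence. Compound 3 is expected to give 80000 nM, between 30000 nM and 200000 nM. The expected step is an at least 1.2-fold lower number from compound 2 to compound 3 (0.09 log units; that floor lies within the scatter).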

Compound 3, concentration for total growth inhibition: 66200 nM
The estimate for compound 3 lay 1.2-fold (0.08 log units) above the measured number, within the range that was stated.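

In this assay, chloro in place of hydrogen gives a 1.4-fold higher number from compound 1 to compound 3 (0.14 log units; within the scatter), so compound 3 cannot be told apart from compound 1, whereas the fluoro of compound 2 gave a step beyond the scatter. A halogen on the aromatic ring therefore does not always move the number away from that of compound 1, with compound 2 as the case against. Replacing 4-fluorophenyl with 2-chlorophenyl gives an at least 1.5-fold lower number from compound 2 to compound 3 (0.17 log units; that floor lies within the scatter), which fixes only a floor and shows no difference beyond the scatter, the anchor being a limit and not a number: the limit of > 100000 nM in this assay, at which 1 of the 3 values shown sits.

Going by these compounds, the halogen and its place change together between compound 2 and compound 3, so the share of each stays open. Also open, on these data alone, is how an amine or a carboxylic acid in place of the halogen would read in this assay.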